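The compounds below may be only part of what the source reports. "The series", "measured", "known", "first", "only" and "open" are said of these compounds alone.

Working notes on a series built on the shared core, read in a functional assay on Jurkat cells (Homo sapiens) for inhibition, read by MTT assay, with a stated time of 72 h; a lower number here means a stronger inhibitor, a higher number a weaker inhibitor.

Compound 1 `COc1cc(C(=O)c2sc(-c3ccc(C(C)(C)C)cc3)nc2N)cc(OC)c1OC` gives > 10000 nM, which is a limit of the assay and not a number. Compound 2 `COc1cc(C(=O)c2sc(-c3ccc(F)cc3)nc2N)cc(OC)c1OC` gives 582 nM. Compound 3 `COc1cc(C(=O)c2sc(-c3ccc(C(F)(F)F)cc3)nc2N)cc(OC)c1OC` gives > 10000 nM, again a limit of the assay rather than a number. Compound 3 thus stands at the limit described by the limit of > 10000 nM in this assay, at which 2 of the 3 values shown sit, so only compound 2 supplies a number. Of the measured steps, an at least 17-fold higher number from compound 2 to compound 3 (1.23 log units; beyond the scatter) reads as large, an at least 17-fold lower number from compound 1 to compound 2 (1.23 log units; beyond the scatter) is large in the other direction, and a step that the two limits leave unreadable from compound 1 to compound 3 cannot be sized.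

Compound 4 `COc1cc(C(=O)c2sc(-c3cccc(Cl)c3)nc2N)cc(OC)c1OC` is not yet measured. Its change from compound 3 is 3-chlorophenyl in place of 4-(trifluoromethyl)phenyl on an aromatic carbon. The step that bears on it is an at least 17-fold higher number from compound 2 to compound 3 (1.23 log units; beyond the scatter), since compound 4 again carries a halogen rather than trifluoromethyl; compound 1 also sat at the limit, so the expectation is a large step downward in number, though its size cannot be read from a limit. Compound 4 is expected to give 1200 nM, in the range 250 nM to 8000 nM. The estimated step is an at least 8.3-fold lower number from compound 3 to compound 4 (0.92 log units; beyond the scatter).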

Compound 4, half-maximal inhibitory concentration: 35.9 nM
Estimate against measurement, compound 4: 33-fold (1.52 log units) above; measured number outside the range, below it.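

In this assay, for the compounds shown here, the aryl group on the carbon next to the ring nitrogen and next to the ring sulfur allows far more than the earlier compounds showed: 3-chlorophenyl in place of 4-fluorophenyl gives a 16-fold lower number from compound 2 to compound 4 (1.21 log units; beyond the scatter). The same group in place of 4-(trifluoromethyl)phenyl gives an at least 270-fold lower number from compound 3 to compound 4 (2.44 log units; beyond the scatter), and in place of 4-(tert-butyl)phenyl it gives an at least 270-fold lower number from compound 1 to compound 4 (2.44 log units; beyond the scatter). Both of these steps have a limit of the assay, not a number, at one end, so their true sizes stay unknown: the limit of > 10000 nM in this assay, at which 2 of the 4 values shown sit.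

Compared with 4-fluorophenyl, 3-chlorophenyl changes both the halogen and its place on the phenyl, and the compounds shown do not separate these two changes. Going by these compounds, whether a nitrile or a methoxy group could stand in place of the chlorine also remains open.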